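This account rests on a few compounds, and the source may have more. Where it says the series, first, only, none or still open, it means among the compounds named here.

Measured so far in an ADME assay on microsomes from liver (Homo sapiens) for metabolic stability; a higher number here means that the compound lasts longer, a lower number that the compound disappears faster:
- compound 1 `CCC(CC)C(/C=C1\OC(=O)NC1=O)c1ccc(-c2ccc3cccc(F)c3c2)[nH]c1=O` gives > 3 h (a limit of the assay)
- compound 2 `C/C(=C1/OC(=O)NC1=O)C(c1ccc(-c2ccc3cccc(F)c3c2)[nH]c1=O)C(C)C` gives > 3 h (a limit of the assay)
- compound 3 `CC(C)[C@H](C[C@H]1OC(=O)NC1=O)c1ccc(-c2ccc3cccc(F)c3c2)[nH]c1=O` gives 1.68 h

Among these three, compound 3 alone carries an actual number, 1.68 h. The other two are reported only as a limit: the limit of > 3 h in this assay, at which 2 of the 3 values shown sit. That leaves compound 3 as the one usable starting point for any comparison in this assay.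

Compound 4 `CC(C)[C@H](C[C@H]1SC(=O)NC1=O)c1ccc(-c2ccc3cccc(F)c3c2)[nH]c1=O` has not yet been measured. It keeps the shared core of compound 3 and changes one group: 2,4-dioxo-1,3-thiazolidin-5-yl in place of 2,4-dioxo-1,3-oxazolidin-5-yl on a saturated chain carbon, two bonds along the chain from an aromatic carbon. In words, 2,4-dioxo-1,3-thiazolidin-5-yl stands in place of 2,4-dioxo-1,3-oxazolidin-5-yl, on a saturated chain carbon, two bonds along the chain from an aromatic carbon.

Among the compounds with values here, no measured pair of compounds shows this exchange, so nothing in the data fixes the size of the step. The expectation is therefore modest, with no shift beyond the usual scatter and only a slight lean towards a shorter half-life. The expected step, a 1.1-fold lower number from compound 3 to compound 4 (0.05 log units; within the scatter), stays within that scatter. For compound 4 the half-life is estimated at 1.5 h, with an expected range from 0.7 h to 3 h.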

Compound 4, half-life: 0.67 h
Compound 4: middle estimate off by 2.2-fold (0.35 log units), on the high side, and the stated range ends above it.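

Within the data shown here, putting 2,4-dioxo-1,3-thiazolidin-5-yl in place of 2,4-dioxo-1,3-oxazolidin-5-yl on a saturated chain carbon, two bonds along the chain from an aromatic carbon, gives the first single change that can be read in this assay, with a 2.5-fold lower number from compound 3 to compound 4 (0.40 log units; beyond the scatter) for this exchange. The two groups agree in ring size and in their counts of hydrogen-bond donors and acceptors, and they differ by a sulfur in place of an oxygen, so this one exchange at this position is enough to move the half-life beyond the scatter. Nothing measured here accounts for the size or direction of this step.

As far as these compounds go, whether the same exchange would move the half-life in the same direction on the unsaturated chains of compound 1 and compound 2 stays open, and a single pair cannot show how general the step is. Also open, from the compounds shown here alone, is how a carboxylic acid or a tetrazole on the same saturated chain carbon would behave in this assay when set against compound 3 and compound 4.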